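Thienylmethyl in Place of Cyclobutylmethyl on a Shared Core

The source may report more compounds than this note shows. Statements on the series, on what has been measured and on what is new or still open speak of the compounds shown alone.

Compound 3 `Cc1nc(NCC2CCC2)nc(N[C@@H]2C[C@H](CO)[C@@H](O)[C@H]2O)c1-c1nc2ccccc2s1` was tested in an ADME assay on cells (Homo sapiens) for cytotoxicity, read by polymerase chain reaction, with a stated time of 3 days; on this read-out higher numbers stand for lower toxicity in this test and lower numbers for higher toxicity in this test. In this test compound 3 gives only a limit, > 25000 nM. Compound 1 `Nc1nc(Cl)c(-c2nc3ccc(F)cc3s2)c(N[C@@H]2C[C@H](CO)[C@@H](O)[C@H]2O)n1` likewise reaches only the limit > 25000 nM. Compound 2 `CCOc1ccc2nc(-c3c(Cl)nc(N)nc3N[C@@H]3C[C@H](CO)[C@@H](O)[C@H]3O)sc2c1` also gives only the limit > 25000 nM. Within the data shown here, the one measured step, a step that the two limits leave unreadable from compound 1 to compound 2, therefore offers no readable size, and all three values sit at the same point, (the limit of > 25000 nM in this assay, at which 3 of the 3 values shown sit). Compound 4 `Cc1nc(NCc2cccs2)nc(N[C@@H]2C[C@H](CO)[C@@H](O)[C@H]2O)c1-c1nc2ccccc2s1` differs from compound 3 by thiophen-2-yl in place of cyclobutyl on a saturated chain carbon bound to a nitrogen on an aromatic ring. Among the measured compounds shown here, no measured step bears on that change, so the account expects no movement beyond the scatter, a step that the limit leaves unreadable from compound 3 to compound 4. For compound 4 the estimate is 30000 nM, with a range from 15000 nM to 60000 nM, most likely reported again only as a limit.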

Compound 4, half-maximal cytotoxic concentration: 6000 nM
Estimate against measurement, compound 4: 5.0-fold (0.70 log units) above, and the stated range ends above it.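

In this assay, thiophen-2-yl in place of cyclobutyl on a saturated chain carbon bound to a nitrogen on an aromatic ring gives an at least 4.1-fold lower number from compound 3 to compound 4 (0.61 log units; beyond the scatter), which shows that a change at this position can move the read-out toward higher toxicity in this test. Compound 4 is the only compound shown whose value is a number and not a limit: the limit of > 25000 nM in this assay, at which 3 of the 4 values shown sit.

From the compounds shown here alone, how a benzyl group, a furan-2-yl group or a longer chain in this place would read remains open. Going by these compounds, whether this change would give a similar step on another core also remains open.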